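This account rests on a few compounds, and the source may have more. Where it says the series, first, only, none or still open, it means among the compounds named here.

Compound 2 `C[C@H](Nc1ncnc(N)c1C#N)c1cc(=O)n2cc(F)ccc2c1-c1cccc(F)c1` gives 79% in an ADME assay on microsomes from liver (Rattus norvegicus), read by LC-MS, using NADPH, with a stated time of 30 min, tested at 1 uM (on this read-out lower numbers stand for a less stable compound and higher numbers for a more stable compound), and of the two numbers recorded it stands nearest to compound 1 `C[C@H](Nc1ncnc(N)c1C#N)c1cc(=O)n2cc(F)ccc2c1-c1ccccc1`, which gives 74%, the pair lying within the scatter of each other. Compound 3 `C[C@H](Nc1ncnc(N)c1C#N)c1cc(=O)n2cc(F)ccc2c1-c1cc(F)cc(F)c1` differs from compound 2 by fluoro in place of hydrogen on an aromatic carbon. Among the compounds with values here, the one measured step of the same kind, a number 5 percentage points higher from compound 1 to compound 2 (within the scatter), stayed within the scatter, so no step beyond the scatter is expected here. The expected step is a number 1 percentage points higher from compound 2 to compound 3 (within the scatter). Compound 3 is therefore estimated at 80%, with a range from 66% to 92%.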

Compound 3, percent of the compound remaining: 60%
Estimate against measurement, compound 3: 20 percentage points above, and the stated range ends above it.
By their numbers in this assay, from the lowest: compound 3; then compounds 1 and 2 (each within the scatter of the next).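

In this assay, the second fluoro on the ring does not behave like the first, which stayed within the scatter: the step is a number 19 percentage points lower from compound 2 to compound 3 (beyond the scatter). Measured against the unsubstituted ring, the change to 3,5-difluorophenyl also gives a number 14 percentage points lower from compound 1 to compound 3 (beyond the scatter), so the effect of fluoro at this ring depends on what the ring already carries in these compounds. Nothing available here explains this drop. Still open, going by these compounds, is whether a chloro, methoxy or nitrile at the same place would keep the stability of compound 2.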